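Moving Bromine from 4-Bromophenyl to 3-Bromophenyl

This account rests on a few compounds, and the source may have more. Where it says the series, first, only, none or still open, it means among the compounds named here.

In an ADME assay on HaCaT cells (Homo sapiens) for cytotoxicity, read by MTT assay, with a stated time of 72 h (on this read-out higher numbers stand for weaker inhibition and lower numbers for stronger inhibition), compound 1 (`COc1ccc(Nc2nnnn2-c2ccccc2F)cc1`) gives 122000 nM, compound 2 (`COc1ccc(Nc2nnnn2-c2ccc(Cl)cc2)cc1`) gives 102000 nM and compound 3 (`COc1ccc(-n2nnnc2Nc2ccc(Br)cc2)cc1`) gives 131000 nM. Compound 3 therefore stands level with the other two, since all these numbers lie within the usual scatter of one another. Compound 4 (`COc1ccc(-n2nnnc2Nc2cccc(Br)c2)cc1`) has the same atoms as compound 3, joined differently: 3-bromophenyl in place of 4-bromophenyl on a nitrogen on an aromatic ring. Within the data shown here, only one measured step bears on this, a 1.2-fold lower number from compound 1 to compound 2 (0.08 log units; within the scatter), which puts 4-chlorophenyl in place of 2-fluorophenyl on an aromatic nitrogen. That step stayed within the scatter, so no shift beyond the scatter, in either direction, is expected in this assay, and the expected step is a 1.1-fold lower number from compound 3 to compound 4 (0.06 log units; within the scatter). Compound 4 is estimated at 115000 nM, with an expected range of 60000 nM to 220000 nM.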

Compound 4, half-maximal inhibitory concentration: 138000 nM
Estimate against measurement, compound 4: 1.2-fold (0.08 log units) below; the range from low to high includes it.
By their numbers in this assay, from the lowest: compounds 2, 1, 3 and 4 (each within the scatter of the next).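

In this assay, 3-bromophenyl in place of 4-bromophenyl gives a 1.1-fold higher number from compound 3 to compound 4 (0.02 log units; within the scatter). The earlier step changed the halogen as well as its place, whereas here the same atoms are only joined differently, and the two compounds still stand level. No available evidence accounts for this result. As far as these compounds go, whether an amine or a carboxylic acid in place of the bromine would move the number beyond the scatter remains open.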